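Tail flick activity of purine-linked amino acid amides

The compounds below may be only part of what the source reports. "The series", "measured", "known", "first", "only" and "open" are said of these compounds alone.

Measured compounds: compound 1 `O=C(CN(c1nc(Cl)nc2[nH]cnc12)C1CC1)N[C@@H](CC(=O)OCc1ccccc1)C(=O)OCc1ccccc1` with 6.68%; compound 2 `CC(C)[C@H](NC(=O)CN(c1ncnc2c1ncn2C1CCCCO1)C1CC1)C(=O)OCc1ccccc1` with 21.1%; compound 3 `O=C(O)CC[C@H](NC(=O)CN(c1nc(Cl)nc2[nH]cnc12)C1CC1)C(=O)O` with 29.5%, all in a functional assay on the whole organism (Tail, strain ICR) with Mus musculus as the target, in the tail flick test, with a stated time of 150 min, at a dose of 25 umol/kg by the oral route; a higher number here means a stronger effect of the compound at the dose given, a lower number a weaker effect.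

Compound 3 gives the highest of the three numbers. Its nearest neighbour is compound 2, which lies within the scatter of it, so no order between these two can be claimed; compound 1 lies beyond the scatter below it. Compound 4 `CC[C@H](C)[C@H](NC(=O)CN(c1nc(Cl)nc2[nH]cnc12)C1CC1)C(=O)O` is not yet measured. It differs from compound 3 as follows: sec-butyl in place of 2-carboxyethyl on a saturated chain carbon bound to an amide-type nitrogen and a carbonyl carbon. Going by the values given here, no step between measured compounds of this kind exists, so the expected step of a number 7.5 percentage points lower from compound 3 to compound 4 (within the scatter) is an estimate that rests on the spread of the three numbers alone, and could be none beyond the scatter or a modest fall. Compound 4 is therefore expected to give 22%, within 8% to 40%.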

Compound 4, a percentage reported as activity, at one dose (the size of the read-out at that dose, not a potency): 6.71%
The estimate for compound 4 lay 15.3 percentage points above the measured number, outside the stated range (below it).
By their numbers in this assay, from the lowest: compounds 1 and 4 (each within the scatter of the next); then compounds 2 and 3 (each within the scatter of the next).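

Putting sec-butyl in place of 2-carboxyethyl on a saturated chain carbon bound to an amide-type nitrogen and a carbonyl carbon gives, in this assay, a number 22.8 percentage points lower from compound 3 to compound 4 (beyond the scatter). Going by these compounds alone, this is the first pair that differs in one place only, and it shows that the read-out at this dose depends on the group held at this carbon. No measurement shown accounts for the step. The compounds shown leave open whether an unbranched butyl chain or a 4-aminobutyl chain at this carbon would stay close to compound 3 or to compound 4.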